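A few compounds are considered here, and "the series" means these few. Any claim that something is new, unique, unknown or untested is made for them only; others in the source may bear on it.

Compound 1 `COC(=O)c1c2c(cc(OC)c1C(=O)c1c(O)cc(C)cc1OC)O[C@H](OC)CS2`: > 100000 nM (a limit)
Compound 2 `COC(=O)c1c2c(cc(OC)c1C(=O)c1c(O)cc(C)cc1OC)OC(OC)CS2`: > 100000 nM (a limit)

In a functional assay, with a stated time of 30 min (a lower number here means a stronger inhibitor, a higher number a weaker inhibitor), compound 2 gives > 100000 nM, which is a limit and not a number. Compound 2 thus stands at the limit of > 100000 nM in this assay, at which 2 of the 2 values shown sit.

Compound 3 `COC(=O)c1c2c(cc(OC)c1C(=O)c1c(O)cc(C)cc1OC)O[C@@H](OC)CS2` changes only the drawing of one centre: the two compounds have the same atoms and bonds; at least one stereo element is drawn with a configuration in one of them and without one in the other: 1 of 1 stereo elements differ; a stereocentre at a saturated ring carbon is drawn without a configuration in compound 2 and R in compound 3.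

Going by the values given here, one measured step bears on this, a step that the two limits leave unreadable from compound 1 to compound 2. It concerns the same stereocentre, and its size cannot be read. It reflects (the fact that one of compounds 1 and 2 is drawn with a defined configuration and the other without, at the place where they differ), so it offers no measured size to carry over. The R form is the one configuration not yet tested, but the values shown give no sign of a change in either direction. The expected outcome for a number no higher from compound 2 to compound 3 (the limit leaves the size open) is no step beyond the scatter. Compound 3 is expected at 100000 nM, with an estimated range of 30000 nM to 200000 nM, most likely reported again only as a limit.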

Compound 3, half-maximal inhibitory concentration: > 100000 nM
Compound 3 was reported as a limit; the forecaster's own chance of this, stated with the estimate: 85%; the middle value lies on the limit itself.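

In this assay compound 3 gives > 100000 nM, a limit and not a number. Going by these compounds alone, no step among compound 1, compound 2 and compound 3 can be read: the limit of > 100000 nM in this assay, at which 3 of the 3 values shown sit. Going by these compounds, whether the configuration at the saturated ring carbon affects inhibition at all remains open.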